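The source may hold more compounds than are shown below. What is called first, only, known or untested is meant among the compounds shown, and "the series" means these compounds.

Measured compounds in this study:
compound 1 `CC(=O)Nc1ccc(-c2nnc(C3(c4ccc(Cl)cc4)CCC3)n2C)c(Cl)c1` — > 4000 nM
compound 2 `Cn1c(-c2ccc(C(N)=O)cc2C(N)=O)nnc1C1(c2ccc(Cl)cc2)CCC1` — > 4000 nM
compound 3 `Cn1c(-c2ccc(C(N)=O)cc2Cl)nnc1C1(c2ccc(Cl)cc2)CCC1` — > 4000 nM

In an assay on isolated protein for inhibition of 11-beta-hydroxysteroid dehydrogenase type 2 (Mus musculus) (a higher number here means a weaker inhibitor, a lower number a stronger inhibitor), compound 1 gives > 4000 nM, which is a limit of the assay and not a number. Compound 2 gives > 4000 nM, also a limit. Compound 3 gives > 4000 nM, again a limit. All three values sit at the limit of > 4000 nM in this assay, at which 3 of the 3 values shown sit, so compound 3 cannot be ranked against compound 1 or compound 2, and the steps a step that the two limits leave unreadable from compound 1 to compound 3 and a step that the two limits leave unreadable from compound 2 to compound 3 are left unreadable. Compound 4 `Cn1c(-c2ccc(C(=O)O)cc2Cl)nnc1C1(c2ccc(Cl)cc2)CCC1` differs from compound 3 by hydroxy in place of amino on a carbonyl carbon. Among the compounds with values here, no measured step touches this change, and those that exist give no size. Compound 4 is therefore expected at 8000 nM, between 2500 nM and 30000 nM, most probably again as a limit. The step is expected to read a step that the limit leaves unreadable from compound 3 to compound 4.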

Compound 4, half-maximal inhibitory concentration: > 4000 nM
Compound 4 ended at the assay's limit; the forecaster's own chance of this, stated with the estimate: 85%; the middle value lies beyond the limit too.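

Neither the step between compound 3 and compound 4 nor that between compound 1 and compound 4 can be read, since every value is a limit: the limit of > 4000 nM in this assay, at which 4 of the 4 values shown sit. The compounds shown leave open whether any of these changes alters inhibition at all.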